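Hydroxyazetidine amide in place of a spiro-oxetane azetidine

The source may report more compounds than this note shows. Statements on the series, on what has been measured and on what is new or still open speak of the compounds shown alone.

Compound 2 `N#CC1(NC(=O)[C@@H]2C[C@@H](S(=O)(=O)c3ccccc3)C[C@H]2C(=O)N2CC3(COC3)C2)CC1` is the weaker of the two measured compounds: in a functional assay on A20 cells (Mus musculus) for inhibition, with stated times of 1 h, 16 h and 24 h (a lower number here means a stronger inhibitor, a higher number a weaker inhibitor), compound 2 gives 248 nM, whereas compound 1 `N#CCNC(=O)[C@@H]1C[C@@H](S(=O)(=O)c2ccccc2Cl)C[C@H]1C(=O)N1CCOCC1` gives 3 nM, a gap well beyond the scatter. Compound 3 `N#CC1(NC(=O)[C@@H]2C[C@@H](S(=O)(=O)c3ccccc3)C[C@H]2C(=O)N2CC(O)C2)CC1` differs from compound 2 by a group of 5 heavy atoms (3 carbon, 1 nitrogen, 1 oxygen; one four-membered non-aromatic ring with 1 hetero atom) in place of a group of 7 heavy atoms (5 carbon, 1 nitrogen, 1 oxygen; 2 four-membered non-aromatic rings with 1 hetero atom each), on a carbonyl carbon. Among the compounds with values here, no measured pair shows the effect of this change, so the step from compound 2 to compound 3 in this assay is expected to be small, at most a modest drop and possibly nothing beyond the scatter, as a 1.6-fold lower number from compound 2 to compound 3 (0.19 log units; within the scatter). Compound 3 is therefore estimated at 160 nM, within 50 nM to 500 nM.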

Compound 3, half-maximal inhibitory concentration: 572 nM
The estimate for compound 3 lay 3.6-fold (0.55 log units) below the measured number, and the stated range ends below it.
By their numbers in this assay, from the lowest: compound 1; then compound 2; then compound 3.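

In this assay, putting the 3-hydroxyazetidin-1-yl group on this carbonyl carbon gives a 2.3-fold higher number from compound 2 to compound 3 (0.36 log units; beyond the scatter), so the position responds to this exchange, modestly but measurably, and in the direction of a weaker inhibitor. The entering group is smaller and carries a hydrogen-bond donor that the leaving group lacks. Nothing available explains the step. The compounds shown leave open whether the hydroxyl itself matters, since no compound here carries an unsubstituted azetidine or a 3-methoxyazetidine on this carbonyl carbon. From the compounds shown here alone, how an open-chain amine such as dimethylamine would fare here also remains unknown.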